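Glycolipid series: the acyl-chain step from compound 2 to compound 4

The source may report more compounds than this note shows. Statements on the series, on what has been measured and on what is new or still open speak of the compounds shown alone.

Measured so far:
compound 1, `CCCCCCCCCCCCCCCCO[C@H]1O[C@H](COCC(CO)(CO)COS(=O)(=O)O)[C@@H](O)[C@H](O)[C@H]1NC(=O)CCCC`, 11 uM
compound 2, `CCCCCCCCCCCCCCCCO[C@H]1O[C@H](COCC(O)CO)[C@@H](O)[C@H](O)[C@H]1NC(=O)CCCC`, "not determined" (no result reported)
compound 3, `CCCCCCCCCCCCCCCCO[C@H]1O[C@H](COC[C@@H](O)CO)[C@@H](O)[C@H](O)[C@H]1NC(=O)CCCC`, "not determined" (no result reported)

Only compound 1 carries a number in a functional assay on C6 cells (Rattus norvegicus), read by thymidine incorporation; a higher number here means a weaker inhibitor, a lower number a stronger inhibitor: compound 1 gives 11 uM. Compound 2 stands without a single number in this assay, and compound 3 likewise has no result to set beside it. Compound 2 and compound 3 differ only in the fact that one of compounds 2 and 3 is drawn with a defined configuration and the other without, at the place where they differ, so nothing about the effect of that difference can be read from the numbers. Within the data shown here, no step between measured compounds is on hand, and compound 1 differs from compound 2 in more than one place, so no measured step bears directly on the change now considered.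

The next compound is compound 4, `CCCCCCCCCCCCCCCCO[C@H]1O[C@H](COCC(O)CO)[C@@H](O)[C@H](O)[C@H]1NC(=O)CCCCCCCCCCCCCCC`. Compared with compound 2 the difference is undecyl in place of hydrogen on a saturated chain carbon, four bonds along the chain from a carbonyl carbon. Without a measured step, the expectation is that compound 4 lands in the same region as compound 1, with the widest plausible spread in either direction rather than a committed move beyond the scatter. In this assay compound 4 is estimated at 10 uM, within a range from 3 uM to 40 uM.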

Compound 4, concentration for 50% inhibition: 2.6 uM
For compound 4 the middle estimate is 3.8-fold (0.59 log units) above the measured one; measured number outside the range, below it.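

In this assay compound 4 gives 2.6 uM while compound 2 has no single number, so no step can be read from this result. The compounds shown leave open what undecyl in place of hydrogen does to inhibition in this series. Nothing on hand bears on the result for compound 4.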